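Cinnamate sulfonate series: cytotoxicity tolerance notes

A few compounds are considered here, and "the series" means these few. Any claim that something is new, unique, unknown or untested is made for them only; others in the source may bear on it.

Measured so far:
compound 1, `COC(=O)/C=C/c1ccc(OS(=O)(=O)c2ccc(Cl)cc2)c(OC)c1` — 99500 nM
compound 2, `COc1cc(/C=C/C(=O)Nc2ccc(I)cc2)ccc1OS(=O)(=O)c1ccc(Cl)cc1` — 39400 nM

In a toxicity assay on L02 cells (Homo sapiens) for cytotoxicity, read by MTT assay, with a stated time of 24 h (a lower number here means that less compound is tolerated, a higher number that more compound is tolerated), compound 1 gives the highest of the two numbers; compound 2 sits nearest, and the step of a 2.5-fold lower number from compound 1 to compound 2 (0.40 log units; beyond the scatter) is modest. Compound 3, `CCCCS(=O)(=O)Oc1ccc(/C=C/C(=O)OC)cc1OC`, differs from compound 1 by butyl in place of 4-chlorophenyl on a sulfonyl sulfur. For the measured compounds named here, no measured step touches the sulfonyl sulfur; the one step known concerns the carbonyl carbon, so nothing bears directly on this change. With no guidance, the expectation is a step of a 1.0-fold higher number from compound 1 to compound 3 (0.00 log units; within the scatter) lying within the scatter. Compound 3 is therefore estimated at 100000 nM, with a range from 40000 nM to 250000 nM.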

Compound 3, half-maximal cytotoxic concentration: 208000 nM
Estimate against measurement, compound 3: 2.1-fold (0.32 log units) below; the range from low to high includes it.
By their numbers in this assay, from the lowest: compound 2; then compound 1; then compound 3.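

On the sulfonyl sulfur, butyl in place of 4-chlorophenyl gives a step in this assay (a 2.1-fold higher number from compound 1 to compound 3 (0.32 log units; beyond the scatter)), so this position also changes the tolerated concentration. For the compounds shown here, the only earlier step, at the carbonyl carbon (a 2.5-fold lower number from compound 1 to compound 2 (0.40 log units; beyond the scatter)), ran in the opposite direction. No available evidence accounts for the size or direction of the sulfonyl step.

Open, on these data alone, is whether a methyl, an unsubstituted phenyl or a longer chain on the sulfonyl sulfur would follow butyl. Also open, as far as these compounds go, is whether the butyl step holds with (4-iodophenyl)amino on the carbonyl carbon.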